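Sulfonamide aryl swap: from difluorophenyl to 3-ethylphenyl

The compounds below may be only part of what the source reports. "The series", "measured", "known", "first", "only" and "open" are said of these compounds alone.

Measured in a functional assay on M21 cells (Homo sapiens) for antiproliferative activity, read by sulforhodamine B assay, with a stated time of 48 h; a lower number here means a stronger inhibitor, a higher number a weaker inhibitor:
- compound 1 `Cc1ccc(NS(=O)(=O)c2ccc(N3CCNC3=O)cc2)cc1C`: 94 nM
- compound 2 `O=C1NCCN1c1ccc(S(=O)(=O)Nc2ccc(F)c(F)c2)cc1`: 220 nM

Among the measured compounds shown here, compound 2 holds the higher of the two numbers so far. For the measured compounds named here, the one measured step is a 2.3-fold higher number from compound 1 to compound 2 (0.37 log units; beyond the scatter), with 3,4-difluorophenyl in place of 3,4-dimethylphenyl on a sulfonamide nitrogen. It is modest but beyond the scatter.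

Compound 3 `CCc1cccc(NS(=O)(=O)c2ccc(N3CCNC3=O)cc2)c1` has not yet been measured. Its difference from compound 2 is as follows: 3-ethylphenyl in place of 3,4-difluorophenyl on a sulfonamide nitrogen. In words, 3-ethylphenyl stands in place of 3,4-difluorophenyl on the same sulfonamide nitrogen.

Going by the values given here, only that one step bears on this change, and no measured compound carries 3-ethylphenyl. The entering group is all carbon, like the 3,4-dimethylphenyl of compound 1 at 94 nM, so a partial return towards that value seems the likeliest outcome in this assay. The expectation is therefore a modest move to a lower number, resting on thin evidence, and the estimated change is a 1.7-fold lower number from compound 2 to compound 3 (0.23 log units; within the scatter). For compound 3 the estimated value is 130 nM, with an expected range of 45 nM to 380 nM.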

Compound 3, half-maximal inhibitory concentration: 82 nM
Compound 3: the middle estimate sits 1.6-fold (0.20 log units) above what was measured; measured number inside the range.
By their numbers in this assay, from the lowest: compounds 3 and 1 (each within the scatter of the next); then compound 2.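

In this assay the exchange of 3,4-difluorophenyl for 3-ethylphenyl gives a 2.7-fold lower number from compound 2 to compound 3 (0.43 log units; beyond the scatter) on the sulfonamide nitrogen, so a second all-carbon substituted phenyl group now separates from 3,4-difluorophenyl by a step beyond the scatter, and that separation no longer rests on the 3,4-dimethylphenyl of compound 1 alone. The two all-carbon groups cannot be told apart, with a 1.1-fold lower number from compound 1 to compound 3 (0.06 log units; within the scatter) and the shared core unchanged, so at this position a single 3-ethyl group serves as well as the 3,4-dimethyl pair in this read-out. Across these three compounds only compound 2 stands apart and none goes against that grouping, but nothing measured says why the fluorine-bearing ring differs from the other two.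

Open, going by these compounds, is whether the gap follows fluorine itself or the absence of a carbon substituent, which a 3-fluorophenyl, 3-chlorophenyl or 3-methoxyphenyl group on the same nitrogen would help to separate. Also open, on these data alone, is how far the 3-substituent can grow or change in kind, for example a 3-propyl chain, a 3-aminophenyl group or a 3-carboxyphenyl group.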